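Methoxy for trifluoromethyl on the pendant phenyl of compound 1

The compounds below may be only part of what the source reports. "The series", "measured", "known", "first", "only" and "open" are said of these compounds alone.

Working notes on the series. Compound 1 `Cc1ccc(S(=O)(=O)Oc2ccc3c(c2C)[C@H](Cn2cc(-c4ccc(C(F)(F)F)cc4)nn2)[C@@]24CC(=O)[C@@](C)(CC[C@@H]32)C4)cc1` has been run in a functional assay on A549 cells (Homo sapiens) for cytotoxicity, read by MTT assay, with a stated time of 4 days; a higher number here means a weaker inhibitor, a lower number a stronger inhibitor. In this assay compound 1 returns only a limit, > 20000 nM. Compound 3 `Cc1c(O)ccc2c1[C@H](Cn1cc(-c3ccc(C(F)(F)F)cc3)nn1)[C@@]13CC(=O)[C@@](C)(CC[C@@H]21)C3` is reached from compound 1 by hydrogen in place of (4-methylphenyl)sulfonyl on an oxygen on an aromatic ring. In this assay compound 3 likewise returns only a limit, > 20000 nM. The step that the two limits leave unreadable from compound 1 to compound 3 therefore has no readable size. Compound 2 `C=C1C[C@]23C[C@@]1(O)CC[C@@H]2c1cccc(C)c1[C@@H]3Cn1cc(-c2ccc(OC)cc2)nn1`, which carries a methoxy group as well, also stands at a limit, > 20000 nM. Among the measured compounds shown here, every value so far sits at the limit of > 20000 nM in this assay, at which 3 of the 3 values shown sit, so the set holds no step whose size can be read.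

Compound 4 `COc1ccc(-c2cn(C[C@H]3c4c(ccc(OS(=O)(=O)c5ccc(C)cc5)c4C)[C@@H]4CC[C@@]5(C)C[C@]43CC5=O)nn2)cc1` follows from compound 1 by the change (methoxy in place of trifluoromethyl on an aromatic carbon). For the measured compounds named here, no measured step addresses methoxy in place of trifluoromethyl directly, and the one step available, from compound 1 to compound 3, is unreadable. With all three measured compounds, compound 2 with its methoxy group among them, at the limit, no step beyond the scatter is expected in this assay in either direction, and a further limit is the likeliest outcome. Compound 4 is expected at 20000 nM, within 8000 nM to 50000 nM. For compound 4 this estimate means the step of a number no higher from compound 1 to compound 4 (the limit leaves the size open).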

Compound 4, half-maximal inhibitory concentration: > 20000 nM
Compound 4 gave a limit, no number; the forecaster's own chance of this, stated with the estimate: 85%; the middle value lies on the limit itself.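

In this assay compound 4 returns only a limit, > 20000 nM. Among the compounds shown here, compound 1 also stands at a limit, and the change from compound 1 to compound 4 yields no step that can be read. The compounds shown leave open whether methoxy and trifluoromethyl on the pendant phenyl differ at all in this assay, because every value stands at one limit: the limit of > 20000 nM in this assay, at which 4 of the 4 values shown sit.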